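The source may report more compounds than this note shows. Statements on the series, on what has been measured and on what is new or still open speak of the compounds shown alone.

- Compound 1 `Cc1cc(N2CC[C@@H](C)[C@@H](N(C)c3ncnc4[nH]ccc34)C2)n2nc(SCc3csc4ccc(Cl)cc34)nc2n1` gives > 100000 nM (a limit of the assay, not a number)
- Compound 2 `Cc1ccc(CSc2nc3nc(C)cc(N4CC[C@@H](C)[C@@H](N(C)c5ncnc6[nH]ccc56)C4)n3n2)cc1` gives 15200 nM (the only actual number)

In a functional assay on HGC-27 cells (Homo sapiens) for inhibition, read by MTT assay, with a stated time of 72 h (on this read-out higher numbers stand for weaker inhibition and lower numbers for stronger inhibition), compound 2 therefore has no measured number to be ranked against. Compound 3 `Cc1cc(N2CC[C@@H](C)[C@@H](N(C)c3ncnc4[nH]ccc34)C2)n2nc(SCc3ccc(Br)cc3)nc2n1` carries one change, bromo in place of methyl on an aromatic carbon in words, bromo in place of methyl on an aromatic carbon, para to a large group. Within the data shown here, the one measured step at this end of the molecule, an at least 6.5-fold lower number from compound 1 to compound 2 (0.81 log units; beyond the scatter), exchanged the whole aromatic group, so it shows that this end can move the read-out but says little about so small a swap. No change beyond the scatter is expected, and the estimated step is a 1.2-fold higher number from compound 2 to compound 3 (0.07 log units; within the scatter) at most in size. For compound 3 the estimate is 18000 nM with an expected range from 7000 nM to 45000 nM in this test.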

Compound 3, half-maximal inhibitory concentration: 19500 nM
Estimate against measurement, compound 3: 1.1-fold (0.03 log units) below; the range from low to high includes it.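

In this assay, bromo in place of methyl on the phenyl ring leaves the read-out within the scatter (a 1.3-fold higher number from compound 2 to compound 3 (0.11 log units; within the scatter)), so the two groups cannot be told apart at this place. The 4-bromophenyl group also stands clearly apart from the 5-chloro-1-benzothiophen-3-yl group of compound 1 (an at least 5.1-fold lower number from compound 1 to compound 3 (0.70 log units; beyond the scatter)), as 4-methylphenyl did. The size of that step stays uncertain, since it rests on a limit of the assay: (the limit of > 100000 nM in this assay, at which 1 of the 3 values shown sits). Going by these compounds, whether an amine or a carboxylic acid at this place on the ring would move the number remains open.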